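The source may hold more compounds than are shown below. What is called first, only, known or untested is meant among the compounds shown, and "the series" means these compounds.

Measured so far:
compound 1, `CN(C)C(=S)N/N=C/c1cnc2ccccc2n1`: 750 nM
compound 2, `COc1cccc(NC(=S)N/N=C/c2ccc3ccccc3n2)c1`: 74500 nM

Both numbers come from a functional assay on HeLa cells (Homo sapiens) for antiproliferative activity, read by sulforhodamine B assay, with a stated time of 72 h; on this read-out higher numbers stand for weaker inhibition and lower numbers for stronger inhibition. Compound 2 stands at the higher of the two numbers, so it is the weaker inhibitor of cell growth; compound 1, which shares no single-point relation with it, gives 750 nM, a gap well beyond the usual scatter.

Compound 3, `S=C(N/N=C/c1ccc2ccccc2n1)Nc1ccccc1`, is the next compound to be measured in this assay. Compared with compound 2 the change is hydrogen in place of methoxy on an aromatic carbon. Among the compounds with values here, no measured pair shows the effect of this change on the shared core, so the expectation rests on the size of the change alone: a small group is removed from the outer ring, and a step of this kind is expected to stay within the scatter, with no clear direction. Compound 3 is therefore expected to give 65000 nM, with a likely range from 25000 nM to 170000 nM, a step of a 1.1-fold lower number from compound 2 to compound 3 (0.06 log units; within the scatter).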

Compound 3, half-maximal inhibitory concentration: 27400 nM
Beside the measured number, compound 3's estimate is 2.4-fold (0.38 log units) above it, and the stated range covers the measured number.
By their numbers in this assay, from the lowest: compound 1; then compound 3; then compound 2.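

In this assay, within the data shown here, compound 2 and compound 3 form the first pair that differs in only one place, so the effect of a single group can now be read directly. Replacing methoxy with hydrogen on this aromatic carbon gives a 2.7-fold lower number from compound 2 to compound 3 (0.43 log units; beyond the scatter), showing that the methoxy group is not needed for the activity of this series and that inhibition is modestly stronger without it. Nothing available here explains why the number moves in this direction.

As far as these compounds go, it remains open whether another group at this place, such as a hydroxyl, an amine or a carboxylic acid, would strengthen or weaken inhibition further. A single pair also cannot show whether the same change would have a similar effect on a different core.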